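From Bromo to Methoxy at the Assay Limit

The source may hold more compounds than are shown below. What is called first, only, known or untested is meant among the compounds shown, and "the series" means these compounds.

In a functional assay on A549 cells (Homo sapiens) for cytotoxicity, read by MTT assay, with a stated time of 72 h (a higher number here means a weaker inhibitor, a lower number a stronger inhibitor), compound 3 (`CNC(=O)c1cc(Oc2ccc(NC(=O)c3cc(-c4ccc(Br)cc4)ncn3)cc2F)ccn1`) gives > 100000 nM, which is a limit and not a number. Compound 1 (`CNC(=O)c1cc(Oc2ccc(NC(=O)c3cc(-c4ccc(Cl)cc4)ncn3)cc2F)ccn1`) gives > 100000 nM, also a limit. Compound 2 (`CNC(=O)c1cc(Oc2ccc(NC(=O)c3cc(-c4ccc(Br)cc4)ncn3)cc2)ccn1`) gives > 100000 nM, again a limit. Compound 4 (`CNC(=O)c1cc(Oc2ccc(NC(=O)c3cc(-c4ccc(OC)cc4)ncn3)cc2F)ccn1`) carries methoxy in place of bromo on an aromatic carbon, para to a large group: methoxy in place of bromo on an aromatic carbon. Among the compounds with values here, two measured steps bear on this change: a step that the two limits leave unreadable from compound 1 to compound 3, at the same place, and a step that the two limits leave unreadable from compound 2 to compound 3, elsewhere. Neither gives a size, and the series offers only (the limit of > 100000 nM in this assay, at which 3 of the 3 values shown sit), so no step beyond the scatter is expected in this assay. The step expected is a number no higher from compound 3 to compound 4 (the limit leaves the size open). Compound 4 is estimated at 100000 nM, within an expected range of 30000 nM to 300000 nM.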

Compound 4, half-maximal inhibitory concentration: 34500 nM
The estimate for compound 4 lay 2.9-fold (0.46 log units) above the measured number; the range from low to high includes it.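

Within the data shown here, compound 4 is the only compound here with a number rather than a limit in this assay, so this place, para to a large group, now shows a readable change. Methoxy in place of bromo gives an at least 2.8-fold lower number from compound 3 to compound 4 (0.46 log units; beyond the scatter), and methoxy in place of chloro gives an at least 2.8-fold lower number from compound 1 to compound 4 (0.46 log units; beyond the scatter). Both sizes remain minimums, and the earlier steps cannot be read, because the other compounds all stand at the same limit: the limit of > 100000 nM in this assay, at which 3 of the 4 values shown sit.

Going by these compounds, whether an amine or a longer chain such as ethoxy at this place would lower the number further remains open. So does what the fluoro contributes when methoxy is present.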